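Removing the Chloro Group: From Compound 1 to Compound 4

A few compounds are considered here, and "the series" means these few. Any claim that something is new, unique, unknown or untested is made for them only; others in the source may bear on it.

In a functional assay on MDA-MB-435S cells (Homo sapiens) for cytotoxicity, read by MTT assay, with a stated time of 72 h (on this read-out lower numbers stand for stronger inhibition and higher numbers for weaker inhibition), compound 1 `Cc1nnc(SCc2coc3ccc(Cl)cc3c2=O)o1` gives 3300 nM. Compound 2 `Cc1nnc(SCc2coc3ccc(Cl)cc3c2=O)s1` carries a 5-methyl-1,3,4-thiadiazol-2-yl in place of the 5-methyl-1,3,4-oxadiazol-2-yl on the sulfur, and in this assay compound 2 gives 2200 nM; the step of a 1.5-fold lower number from compound 1 to compound 2 (0.18 log units; within the scatter) is small, so the two compounds count as equal here. Compound 3 `Cc1cc(C)n2nc(SCc3nnc(SCc4cc(=O)c5ccccc5o4)s3)nc2n1`, a larger compound built on a different core, reaches only the limit of this assay, where compound 3 gives > 25000 nM, which is a limit and not a number (the limit of > 25000 nM in this assay, at which 1 of the 3 values shown sits). Among the two numbers actually measured, compound 1 has the higher one, with compound 2 within the scatter of it.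

Compound 4 `Cc1nnc(SCc2coc3ccccc3c2=O)o1` differs from compound 1 in a single place: hydrogen in place of chloro on an aromatic carbon. For the measured compounds named here, none of the measured steps touches this chloro group; the only one-place step, a 1.5-fold lower number from compound 1 to compound 2 (0.18 log units; within the scatter), exchanges the five-membered ring on the sulfur and stays within the scatter, so it offers no direct guide to the change at hand. Without such a guide, the expected step of a 1.5-fold higher number from compound 1 to compound 4 (0.18 log units; within the scatter) is modest, leaning towards a somewhat higher number, meaning weaker inhibition, while a result within the scatter remains fully possible. Compound 4 is therefore expected to give about 5000 nM, with a plausible range from 2000 nM to 15000 nM in this assay.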

Compound 4, half-maximal inhibitory concentration: 1200 nM
For compound 4 the middle estimate is 4.2-fold (0.62 log units) above the measured one; measured number outside the range, below it.
By their numbers in this assay, from the lowest: compounds 4, 2 and 1 (each within the scatter of the next, the first and the last beyond it). At a limit, above all of these: compound 3.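

In this assay, for the compounds shown here, hydrogen in place of chloro on this aromatic carbon brings a 2.8-fold lower number from compound 1 to compound 4 (0.44 log units; beyond the scatter), the first measured step that touches this position. The chloro group is therefore not required for compound 1 to show cytotoxicity on these cells, and on this core, taking it away gives a modest gain in inhibition rather than a loss, although this rests on a single pair of compounds. Nothing given here accounts for why removing this one chlorine atom moves the number in this direction.

The compounds shown leave open how other groups on this same carbon would behave, such as fluoro, methoxy or an amine, and so whether hydrogen is better than chloro only or better than substituents in general. They also leave open whether the same exchange of chloro for hydrogen would lower the number to a similar extent when the sulfur carries the 5-methyl-1,3,4-thiadiazol-2-yl of compound 2 rather than the 5-methyl-1,3,4-oxadiazol-2-yl of compound 1.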